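The source may hold more compounds than are shown below. What is called first, only, known or untested is meant among the compounds shown, and "the series" means these compounds.

In a functional assay on HeLa cells (Homo sapiens) for antiproliferative activity, with a stated time of 48 h (a higher number here means a weaker inhibitor, a lower number a stronger inhibitor), compound 1 (`C=C(Br)C(=O)Nc1ccc(C(=O)/C=C/c2ccc(OC)cc2OC)cc1`) gives 1100 nM, while compound 2 (`COc1ccccc1/C=C/C(=O)c1ccc(N)cc1`) gives 7800 nM, the higher of the two numbers, with a gap beyond the scatter. Compound 3 (`COc1ccc(/C=C/C(=O)c2ccc(N)cc2)c(OC)c1`) differs from compound 2 by a single change: methoxy in place of hydrogen on an aromatic carbon. Among the measured compounds shown here, no measured step isolates this change. Compound 1, at 1100 nM, carries the same methoxy but also differs elsewhere, so only a small move toward a lower number is expected, estimated as a 1.6-fold lower number from compound 2 to compound 3 (0.19 log units; within the scatter). In this assay, the estimate for compound 3 is 5000 nM, with an expected range of 2000 nM to 12000 nM.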

Compound 3, half-maximal inhibitory concentration: 22000 nM
Compound 3: middle estimate off by 4.4-fold (0.64 log units), on the low side; the measured number lies above the stated range.
By their numbers in this assay, from the lowest: compound 1; then compound 2; then compound 3.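

In this assay, a methoxy in place of hydrogen on the aromatic carbon meta to a methoxy group and para to a large group weakens the compound, giving a 2.8-fold higher number from compound 2 to compound 3 (0.45 log units; beyond the scatter). With this methoxy present, hydrogen in place of (1-bromoethenyl)carbonyl on the nitrogen gives a 20-fold higher number from compound 1 to compound 3 (1.30 log units; beyond the scatter), so the low number of compound 1 comes with that acyl group and not with the methoxy. No measurement bears on the reason for either step. Going by these compounds, it remains open whether a hydroxyl or an ethoxy at this position would behave like the methoxy, and whether a plain acetyl on the nitrogen would match (1-bromoethenyl)carbonyl.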